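The compounds below may be only part of what the source reports. "The series", "measured", "known", "first", "only" and "open" are said of these compounds alone.

The measured compounds in an assay on isolated protein for inhibition of sodium channel protein type 4 subunit alpha (Homo sapiens); a higher number here means that more compound is needed for the effect, a lower number that less compound is needed:

Compound 1, `Cc1cccc(C)c1OC[C@H](N)c1ccccc1`, gives 3020 nM.
Compound 2, `Cc1cc(Cl)cc(C)c1OC[C@H](N)c1ccccc1`, gives 19500 nM.
Compound 3, `Cc1cc(Cl)cc(C)c1OC[C@@H](N)c1ccccc1`, gives 7940 nM.

Compound 2 stands with the highest of these three numbers; its nearest neighbour is compound 3, and compound 1 lies furthest from it. Two steps are known. Adding chloro in place of hydrogen on an aromatic carbon gave a 6.5-fold higher number from compound 1 to compound 2 (0.81 log units; beyond the scatter). The pair of compound 2 and compound 3 rests on (the fact that compounds 2 and 3 differ only in the configuration as drawn), and that change gave a 2.5-fold lower number from compound 2 to compound 3 (0.39 log units; beyond the scatter).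

Compound 4, `Cc1cc(Cl)ccc1OC[C@H](N)c1ccccc1`, differs from compound 2 by hydrogen in place of methyl on an aromatic carbon. Neither measured step concerns a methyl, so there is no direct guide. Removal of a methyl that sits ortho to the large group is taken as a modest loss, so compound 4 is expected to show a 1.6-fold higher number from compound 2 to compound 4 (0.22 log units; within the scatter) in this assay. The estimate for compound 4 in this assay is therefore 32000 nM, within a range from 10000 nM to 100000 nM.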

Compound 4, half-maximal effective concentration: 15100 nM
For compound 4 the middle estimate is 2.1-fold (0.33 log units) above the measured one, and the stated range covers the measured number.
By their numbers in this assay, from the lowest: compound 1; then compounds 3, 4 and 2 (each within the scatter of the next, the first and the last beyond it).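

In this assay, hydrogen in place of methyl on this aromatic carbon, ortho to a large group, gave a 1.3-fold lower number from compound 2 to compound 4 (0.11 log units; within the scatter) and so stayed within the scatter. The two earlier single changes had both gone beyond it: the chloro step gave a 6.5-fold higher number from compound 1 to compound 2 (0.81 log units; beyond the scatter) and the change of configuration gave a 2.5-fold lower number from compound 2 to compound 3 (0.39 log units; beyond the scatter). This position is therefore the first place in the series where a change leaves the number unmoved, at least with the chloro group present and with the configuration of compound 2.

Going by these compounds, it remains open whether the same exchange would read alike in the other configuration or without the chloro group, and whether an ethyl, a methoxy or a trifluoromethyl group at this position would do the same. Nothing at hand bears on why this methyl makes so little difference.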